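This account rests on a few compounds, and the source may have more. Where it says the series, first, only, none or still open, it means among the compounds named here.

Within the data shown here, compound 1 `C/C=C1/[C@H](O[C@@H]2O[C@H](COC(C)=O)[C@@H](OC(C)=O)[C@H](OC(C)=O)[C@H]2OC(C)=O)OC=C(C(=O)OC)[C@H]1CC(=O)OCCCCCCCCCCCCCCC` is the one compound here with a numerical result: in a functional assay on SK-BR-3 cells (Homo sapiens) for antiproliferative activity, read by MTT assay, with a stated time of 72 h (on this read-out lower numbers stand for stronger inhibition and higher numbers for weaker inhibition), compound 1 gives 3810 nM. Compound 2 `C/C=C1/[C@H](O[C@@H]2O[C@H](COC(C)=O)[C@@H](OC(C)=O)[C@H](OC(C)=O)[C@H]2OC(C)=O)OC=C(C(=O)OC)[C@H]1CC(=O)O` shares no counted difference with compound 1; how the two cores differ is not broken down here. In this assay compound 2 reaches only a limit, > 15000 nM. Compound 3 `C/C=C1/[C@H](O[C@@H]2O[C@H](COC(C)=O)[C@@H](OC(C)=O)[C@H](OC(C)=O)[C@H]2OC(C)=O)OC=C(C(=O)O)[C@H]1CC(=O)O` likewise reaches only a limit in this assay, > 20000 nM. The change from compound 2 to compound 3 is hydrogen in place of methyl on an oxygen next to a carbonyl group, and its step is a step that the two limits leave unreadable from compound 2 to compound 3, since one value sits at the limit of > 15000 nM in this assay, at which 1 of the 3 values shown sits, and the other at the limit of > 20000 nM in this assay, at which 1 of the 3 values shown sits. Compound 4 `C/C=C1/[C@H](O[C@@H]2O[C@H](COC(C)=O)[C@@H](OC(C)=O)[C@H](OC(C)=O)[C@H]2OC(C)=O)OC=C(C(=O)O)[C@H]1CC(=O)OCCCCCCCCCCCCCCC` carries the same change from compound 1, (hydrogen in place of methyl on an oxygen next to a carbonyl group). Its step is expected to be a 2.4-fold higher number from compound 1 to compound 4 (0.37 log units; beyond the scatter), resting on compound 1 at 3810 nM alone, as the earlier step is unreadable. Compound 4 is therefore estimated at 9000 nM, between 3500 nM and 25000 nM.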

Compound 4, half-maximal inhibitory concentration: > 20000 nM
Compound 4: only a limit was reported; the forecaster's own chance of this, stated with the estimate: 30%; middle value at least 2.2-fold (0.34 log units) away from the limit.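

On the core of compound 1, the change of methoxycarbonyl to carboxy gives an at least 5.2-fold higher number from compound 1 to compound 4 (0.72 log units; beyond the scatter) in this assay. On these data alone, compound 4 reaches only a limit, > 20000 nM, so the full size of this step stays unknown. The same change from compound 2 to compound 3 cannot be read, as both values are limits, so the step is readable on one core only and the data do not show whether its size carries over to the other core.

As far as these compounds go, whether an ethyl ester or an amide in place of the methoxycarbonyl group would keep the value of compound 1, 3810 nM, stays open. So does the effect of a shorter or a longer chain on the other ester.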